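Removing the Chloro Group from Compound 1

The source may report more compounds than this note shows. Statements on the series, on what has been measured and on what is new or still open speak of the compounds shown alone.

Compound 1 `CC1=NN(c2cccc(Cl)c2)C(=O)C12C=CC(=O)C=C2c1ccc(C)cc1` is the most potent of the numbered measurements in a functional assay on MDA-MB-231 cells (Homo sapiens) for antiproliferative activity, read by CCK-8 assay, with a stated time of 72 h; on this read-out higher numbers stand for weaker inhibition and lower numbers for stronger inhibition: compound 1 gives 3820 nM. Compound 2 `CC1=NN(c2ccc(Cl)cc2)C(=O)C12C=CC(=O)C=C2c1cccc(C)c1` gives 26900 nM in this assay, a number that lies beyond the scatter above that of compound 1. Compound 3 `CC1=NN(c2ccc(Cl)cc2)C(=O)C12C=CC(=O)C=C2c1ccccc1` reaches only a limit of the assay, > 100000 nM, and so carries no number.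

Among the measured compounds shown here, the one single-point step among the measured compounds is an at least 3.7-fold higher number from compound 2 to compound 3 (0.57 log units; beyond the scatter); its endpoint sits at the limit of > 100000 nM in this assay, at which 1 of the 3 values shown sits, so its true size is unknown beyond being at least modest.

Compound 4 `CC1=NN(c2ccccc2)C(=O)C12C=CC(=O)C=C2c1ccc(C)cc1` differs from compound 1 by hydrogen in place of chloro on an aromatic carbon. For the measured compounds named here, no measured step removes a chloro group, and the one known step concerns a methyl on a different aromatic ring, so it bears on the question only loosely: trimming a small substituent from an aryl group of this core weakened inhibition there. A modest weakening is therefore expected for compound 4 as well, with wide uncertainty, as a 2.6-fold higher number from compound 1 to compound 4 (0.42 log units; beyond the scatter). In this assay compound 4 is estimated to give 10000 nM, within a range from 3000 nM to 40000 nM.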

Compound 4, half-maximal inhibitory concentration: 91900 nM
Compound 4: middle estimate off by 9.2-fold (0.96 log units), on the low side; the measured number lies above the stated range.
By their numbers in this assay, from the lowest: compound 1; then compound 2; then compound 4. At a limit, above all of these: compound 3.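

On the phenyl ring that carries the chloro group in compound 1, the change to hydrogen is a large one in this assay: a 24-fold higher number from compound 1 to compound 4 (1.38 log units; beyond the scatter). This is the first step shown on that ring, and with real numbers at both ends its size is known, so the 3-chlorophenyl group of compound 1 accounts for much of the inhibition seen for that compound in this series. Among the compounds shown here, the only other step, an at least 3.7-fold higher number from compound 2 to compound 3 (0.57 log units; beyond the scatter), ends at a limit, so its true size stays open and it cannot be ranked against this one: the limit of > 100000 nM in this assay, at which 1 of the 4 values shown sits.

Going by these compounds, what remains open is whether the gain belongs to chloro itself or to any group at this place, a question that a fluoro, methoxy, amine or carboxylic acid group on the same carbon would help to settle. Equally open, on these data alone, is whether removing the chloro group costs as much when the other aryl ring carries its methyl elsewhere or carries none, and whether the step holds in cell lines other than this one.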